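Chloro to nitro exchange carried onto a second core

The source may hold more compounds than are shown below. What is called first, only, known or untested is meant among the compounds shown, and "the series" means these compounds.

Compound 1 `COc1ccc(N(C)c2ccnc(Cl)n2)cc1Cl` and compound 3 `COc1ccc(N(C)c2cc(C)nc(C)n2)cc1Cl` carry the same chloro group on the outer ring but differ in their cores; the difference between the two cores is not broken down here. In a functional assay on HeLa cells (Homo sapiens) for antiproliferative activity, read by MTT assay, with a stated time of 48 h (on this read-out higher numbers stand for weaker inhibition and lower numbers for stronger inhibition), compound 1 gives 517 nM and compound 3 gives 316 nM; these two numbers lie within the usual scatter of each other, so no order between them is claimed. Compound 2 `COc1ccc(N(C)c2ccnc(Cl)n2)cc1[N+](=O)[O-]` derives from compound 1 by nitro in place of chloro on an aromatic carbon. In this assay compound 2 gives 4730 nM, and the step of a 9.1-fold higher number from compound 1 to compound 2 (0.96 log units; beyond the scatter). Compound 4 `COc1ccc(N(C)c2cc(C)nc(C)n2)cc1[N+](=O)[O-]` carries the same kind of change on the core of compound 3: nitro in place of chloro on an aromatic carbon. The surroundings are described somewhat differently in the two cases, the replaced chloro being meta to a group of 9 heavy atoms in compound 1 but meta to a large group in compound 3, while in both it is ortho to a methoxy group. Among the measured compounds shown here, whether the step repeats on this core is not yet known, and only one example of the change has been measured. Compound 4 is expected to give 2900 nM in this assay, within an estimated range of 1200 nM to 7000 nM. This expectation rests on the step of a 9.1-fold higher number from compound 1 to compound 2 (0.96 log units; beyond the scatter) and on compound 3 with its value 316 nM. The expected step is a 9.2-fold higher number from compound 3 to compound 4 (0.96 log units; beyond the scatter).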

Compound 4, half-maximal inhibitory concentration: 3720 nM
Beside the measured number, compound 4's estimate is 1.3-fold (0.11 log units) below it; low and high end bracket the measured number.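

In this assay, nitro in place of chloro on the core of compound 3 gives a 12-fold higher number from compound 3 to compound 4 (1.07 log units; beyond the scatter), so the weakening seen on the first core appears again on the second and the step is beyond the scatter on both. Set side by side, the two steps do not differ in size, and on these two cores the exchange carries over with its size intact: the same change on two cores in this assay, a 9.1-fold higher number (0.96 log units; beyond the scatter) from compound 1 to compound 2 and a 12-fold higher number (1.07 log units; beyond the scatter) from compound 3 to compound 4, 1.3-fold (0.11 log units) apart, within the scatter of two such steps This agreement rests on just two pairs in a single cell assay, both with the exchanged group ortho to a methoxy group, so it does not show that the step would hold on other cores or in other assays, and it says nothing about why nitro reads weaker than chloro here.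

The compounds shown leave open how an amine, a nitrile or a carboxylic acid at this same aromatic carbon would read in this assay on either core, since only chloro and nitro are compared there. They also leave open whether the step would keep its size on a third core, or with an ethoxy group or a longer chain in place of the methoxy group.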